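Closing a ring at the hydroxyl-bearing carbon of compound 3

The source may hold more compounds than are shown below. What is called first, only, known or untested is meant among the compounds shown, and "the series" means these compounds.

Of the compounds shown here, three built on one shared core have been tested in a functional assay on the whole organism with Rattus norvegicus as the target, with a stated time of 18 h, at a dose of 3 mg/kg by the oral route; on this read-out higher numbers stand for a weaker effect at the one dose given and lower numbers for a stronger effect. Compound 1 `CC1(C)C[C@@H](NC(=O)c2cn[nH]c2)c2cc(-c3ccc(Cl)cc3)c(-c3ccc(Cl)cc3Cl)nc2O1` gives -3%. Compound 2 `CC1(C)CC(NC(=O)C(C)(O)C(F)(F)F)c2cc(-c3ccc(Cl)cc3)c(-c3ccc(Cl)cc3Cl)nc2O1` gives -27%. Compound 3 `CC1(C)CC(NC(=O)C(C)(C)O)c2cc(-c3ccc(Cl)cc3)c(-c3ccc(Cl)cc3Cl)nc2O1` gives -48%, the lowest of the three numbers and therefore the strongest effect among them, with compound 2 nearest and compound 1 furthest away. Within the data shown here, only one pair differs in a single place: a number 21 percentage points lower from compound 2 to compound 3 (beyond the scatter), a modest strengthening that lies beyond the scatter.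

Compound 4 `CC1(C)CC(NC(=O)C2(O)CC2)c2cc(-c3ccc(Cl)cc3)c(-c3ccc(Cl)cc3Cl)nc2O1` differs from compound 3 at the carbonyl carbon alone: 1-hydroxycyclopropyl in place of 1-hydroxy-1-methylethyl on a carbonyl carbon. Among the measured compounds shown here, no measured step matches this exchange. The step from compound 2 to compound 3 altered the same saturated chain carbon bound to a carbonyl carbon, but it swapped trifluoromethyl for methyl rather than tying two carbons into a three-membered ring, so it serves only as a loose guide. A step within the scatter, or at most a small weakening, is expected: a number 8 percentage points higher from compound 3 to compound 4 (within the scatter). Compound 4 is estimated at -40%, with a range from -65% to -15%.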

Compound 4, a percentage reported as activity, at one dose (the size of the read-out at that dose, not a potency): -74%
For compound 4 the middle estimate is 34 percentage points above the measured one; measured number outside the range, below it.
By their numbers in this assay, from the lowest: compound 4; then compound 3; then compound 2; then compound 1.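

In this assay, replacing 1-hydroxy-1-methylethyl with 1-hydroxycyclopropyl on the carbonyl carbon gives a number 26 percentage points lower from compound 3 to compound 4 (beyond the scatter) even though the heavy-atom count and the numbers of hydrogen-bond donors and acceptors stay the same, so at this position a ring alone can change the read-out beyond the scatter. Against 1-hydroxy-1-(trifluoromethyl)ethyl the same ring gives a number 47 percentage points lower from compound 2 to compound 4 (beyond the scatter) and a larger step, which puts compound 4 lowest among the three compounds with a hydroxyl-bearing carbon on the carbonyl. No measurement here explains this gain.

From the compounds shown here alone, whether a three-membered ring is specifically needed remains open, as 1-hydroxycyclobutyl would test that, and so does the role of the hydroxyl, which an amine on the same ring carbon would probe. Going by these compounds, with one dose and one time, how these differences would hold across other doses or times also remains unknown.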